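A few compounds are considered here, and "the series" means these few. Any claim that something is new, unique, unknown or untested is made for them only; others in the source may bear on it.

Working notes on the series in a functional assay on SW1573 cells (Homo sapiens) for antiproliferative activity, read by sulforhodamine B assay, with a stated time of 48 h; a higher number here means a weaker inhibitor of growth, a lower number a stronger inhibitor of growth.

Compound 1 `CCCC(C#CC(=O)OC)O/C=C/C(=O)OC` gives 320 nM. Compound 2 `COC(=O)C#CC(O/C=C/C(=O)OC)C(C)(C)C` gives 3000 nM. Among the measured compounds shown here, the one completed step, tert-butyl in place of propyl on a saturated chain carbon bound to an oxygen on an unsaturated carbon and a triple-bonded carbon, is a 9.4-fold higher number from compound 1 to compound 2 (0.97 log units; beyond the scatter). For the measured compounds named here, of the two measured compounds, compound 2 therefore stands at the higher number, with compound 1 its only neighbour at a lower one.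

Compound 3 `COC(=O)C#CC(C)O/C=C/C(=O)OC` is not yet measured. Its difference from compound 2 is methyl in place of tert-butyl on a saturated chain carbon bound to an oxygen on an unsaturated carbon and a triple-bonded carbon. Going by the values given here, the only step that bears on it is the one from compound 1 to compound 2, which also altered the group at this saturated chain carbon and carried a change beyond the scatter. Since compound 3 moves away from tert-butyl rather than toward it, the expectation is a step back in the other direction, toward or past the number of compound 1, while the exact size is uncertain with a single precedent. The estimate for compound 3 is 400 nM, with a range of 130 nM to 1300 nM, corresponding to an expected 7.5-fold lower number from compound 2 to compound 3 (0.88 log units; beyond the scatter).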

Compound 3, concentration for 50% growth inhibition: 1700 nM
Estimate against measurement, compound 3: 4.3-fold (0.63 log units) below; the measured number lies above the stated range.
By their numbers in this assay, from the lowest: compound 1; then compounds 3 and 2 (each within the scatter of the next).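

In this assay, the new step of a 1.8-fold lower number from compound 2 to compound 3 (0.25 log units; within the scatter) shows that methyl in place of tert-butyl at this saturated chain carbon gives no change that can be told from the scatter, so compound 2 and compound 3 cannot be ranked against each other. The other new step, a 5.3-fold higher number from compound 1 to compound 3 (0.73 log units; beyond the scatter), is beyond the scatter and has the same direction as a 9.4-fold higher number from compound 1 to compound 2 (0.97 log units; beyond the scatter), so compound 1, with its propyl group, now stands apart from both, and the smaller methyl and the larger tert-butyl each go with a higher number. Across these three compounds the number therefore does not follow the heavy-atom count of the group in a single direction, and nothing at hand gives a reason for the standing of compound 1.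

From the compounds shown here alone, with only methyl, propyl and tert-butyl at this position, it remains open whether the low number is particular to propyl or extends to ethyl, to a longer chain such as butyl or pentyl, or to branched isopropyl. Going by these compounds, it is equally open whether a cyclopropyl or phenyl group at this carbon would stay near compound 1 or move towards compound 2 and compound 3.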